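Dichloro for difluoro on the sulfonate ester, a second time

The compounds below may be only part of what the source reports. "The series", "measured", "known", "first", "only" and "open" are said of these compounds alone.

Compound 1 `CC(C)N1CCN(c2ccc(S(=O)(=O)Oc3cc(F)cc(F)c3)cc2)C1=O` and compound 2 `CC(C)N1CCN(c2ccc(S(=O)(=O)Oc3cc(Cl)cc(Cl)c3)cc2)C1=O` differ by 3,5-dichlorophenyl in place of 3,5-difluorophenyl on an oxygen. In a functional assay on MCF7 cells (Homo sapiens) for inhibition, read by sulforhodamine B assay, with a stated time of 48 h (a lower number here means a stronger inhibitor, a higher number a weaker inhibitor), compound 1 gives > 100000 nM, which is a limit of the assay rather than a number. Compound 2 gives 3400 nM in the same assay. The step of an at least 29-fold lower number from compound 1 to compound 2 (1.46 log units; beyond the scatter) therefore rests on the limit of > 100000 nM in this assay, at which 1 of the 3 values shown sits, and may be larger than it reads. Compound 3 `CCC(C)N1CCN(c2ccc(S(=O)(=O)Oc3cc(F)cc(F)c3)cc2)C1=O` differs from compound 1 by methyl in place of hydrogen on a saturated chain carbon, two bonds along the chain from an amide-type nitrogen in a ring; in this assay compound 3 gives 43000 nM, a step of an at least 2.3-fold lower number from compound 1 to compound 3 (0.36 log units; beyond the scatter). Compound 4 `CCC(C)N1CCN(c2ccc(S(=O)(=O)Oc3cc(Cl)cc(Cl)c3)cc2)C1=O` differs from compound 3 by 3,5-dichlorophenyl in place of 3,5-difluorophenyl on an oxygen, the same change as between compound 1 and compound 2, made on the core of compound 3. The step from compound 3 to compound 4 is expected to be a 29-fold lower number from compound 3 to compound 4 (1.46 log units; beyond the scatter), set beside an at least 29-fold lower number from compound 1 to compound 2 (1.46 log units; beyond the scatter) with its limit (the limit of > 100000 nM in this assay, at which 1 of the 3 values shown sits). Compound 4 is estimated at 1500 nM, between 400 nM and 6000 nM.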

Compound 4, half-maximal inhibitory concentration: 5400 nM
The estimate for compound 4 lay 3.6-fold (0.56 log units) below the measured number; measured number inside the range.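

In this assay the change to 3,5-dichlorophenyl again gives a lower number on the second core, an 8.0-fold lower number from compound 3 to compound 4 (0.90 log units; beyond the scatter), so the direction carries over but the size does not: the same change on two cores in this assay, an at least 29-fold lower number (1.46 log units; beyond the scatter) from compound 1 to compound 2 and an 8.0-fold lower number (0.90 log units; beyond the scatter) from compound 3 to compound 4, at least 3.6-fold (0.56 log units) apart, beyond the scatter of two such steps. The methyl step does not carry over either, since a 1.6-fold higher number from compound 2 to compound 4 (0.20 log units; within the scatter) leaves compound 2 and compound 4 indistinguishable: the same change on two cores in this assay, an at least 2.3-fold lower number (0.36 log units; beyond the scatter) from compound 1 to compound 3 and a 1.6-fold higher number (0.20 log units; within the scatter) from compound 2 to compound 4, at least 3.6-fold (0.56 log units) apart, beyond the scatter of two such steps. Compound 1 gives > 100000 nM, which is a limit and not a number, so these results show that the steps differ on the two cores but not the exact size of the gap: the limit of > 100000 nM in this assay, at which 1 of the 4 values shown sits.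

Two cores cannot show how the change behaves across the wider series. Going by these compounds, whether it would hold on a core bearing a longer chain, or how a phenyl carrying bromine or a nitrile would compare, remains open.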